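The source may report more compounds than this note shows. Statements on the series, on what has been measured and on what is new or still open speak of the compounds shown alone.

Measured in a functional assay on HEL cells (Homo sapiens); a higher number here means that more compound is tolerated, a lower number that less compound is tolerated:
Compound 1 `Cc1cn([C@@H]2O[C@H](CO[Si](C)(C)C(C)(C)C)[C@@]3(OS(=O)(=O)C=C3NCC(=O)O)[C@H]2O[Si](C)(C)C(C)(C)C)c(=O)n(C)c1=O`: 136000 nM
Compound 2 `Cc1cn([C@@H]2O[C@H](CO[Si](C)(C)C(C)(C)C)[C@@]3(OS(=O)(=O)C=C3NC(N)=O)[C@H]2O[Si](C)(C)C(C)(C)C)c(=O)n(C)c1=O`: 11000 nM
Compound 3 `COC(=O)NC1=CS(=O)(=O)O[C@@]12[C@@H](CO[Si](C)(C)C(C)(C)C)O[C@@H](n1cc(C)c(=O)n(C)c1=O)[C@@H]2O[Si](C)(C)C(C)(C)C`: > 200000 nM (a limit)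

For compound 3, the reading of > 200000 nM is only a limit. Compound 4 `Cc1cn([C@@H]2O[C@H](CO[Si](C)(C)C(C)(C)C)[C@@]3(OS(=O)(=O)C=C3NCCC(=O)OCc3ccccc3)[C@H]2O[Si](C)(C)C(C)(C)C)c(=O)n(C)c1=O` carries 2-(benzyloxycarbonyl)ethyl in place of methoxycarbonyl on an amine nitrogen. Two measured swaps at this nitrogen bear on the change: an at least 18-fold higher number from compound 2 to compound 3 (1.25 log units; beyond the scatter) is large, while an at least 1.4-fold higher number from compound 1 to compound 3 (0.16 log units; that floor lies within the scatter) is not beyond the scatter. Compound 1, with carboxymethyl on that nitrogen, seems the closest guide at 136000 nM, though compound 2 shows that this position can move the number a long way. A moderate drop is therefore expected, an at least 2.5-fold lower number from compound 3 to compound 4 (0.39 log units; beyond the scatter). Compound 4 is estimated at 80000 nM, with an expected range of 20000 nM to 200000 nM.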

Compound 4, half-maximal cytotoxic concentration: 200000 nM
Compound 4: middle estimate off by 2.5-fold (0.40 log units), on the low side; the measured number falls inside the stated range.
By their numbers in this assay, from the lowest: compound 2; then compounds 1 and 4 (each within the scatter of the next).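

In this assay, a far larger group on this amine nitrogen, one that brings an aromatic ring, does not follow the carbamoyl result: the step is large, with an 18-fold higher number from compound 2 to compound 4 (1.26 log units; beyond the scatter). Set against the carboxymethyl group, it gives a 1.5-fold higher number from compound 1 to compound 4 (0.17 log units; within the scatter), so the low number of compound 2 is not matched by either of these two chains. The reading for compound 3 is a limit, which leaves only a number no higher from compound 3 to compound 4 (the limit leaves the size open), and the size of that step cannot be read: the limit of > 200000 nM in this assay, at which 1 of the 4 values shown sits.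

Going by these compounds, it remains open whether 2-carboxyethyl or plain benzyl on this nitrogen would stay with compound 1 and compound 4 or move toward compound 2.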